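Moving the methyl along the unsaturated acid chain

The compounds below may be only part of what the source reports. "The series", "measured", "known", "first", "only" and "open" are said of these compounds alone.

In an ADME assay on the whole organism (strain CD-1) for pharmacokinetics, with Mus musculus as the target, at a dose of 3 mg/kg by the intravenous route (a higher number here means more compound in the circulation at the dose given, a lower number less compound in the circulation), compound 1 `CN(Cc1ccccc1OCCCCCC(=O)O)C(=O)c1ccc(-c2ccco2)cc1` gives 1100 ng.h/mL and compound 2 `CC(CCCCOc1ccccc1CN(C)C(=O)c1ccc(-c2ccco2)cc1)C(=O)O` gives 11400 ng.h/mL on the shared core, while compound 3 `C/C(=C\CCCOc1ccccc1CN(C)C(=O)c1ccc(-c2ccco2)cc1)C(=O)O` gives 1300 ng.h/mL on the same core. Compound 3 stands low among these three numbers: the data show a 1.2-fold higher number from compound 1 to compound 3 (0.07 log units; within the scatter) as a step within the scatter and an 8.8-fold lower number from compound 2 to compound 3 (0.94 log units; beyond the scatter) as a step beyond it.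

In compound 4 `C/C(=C\C(=O)O)CCCOc1ccccc1CN(C)C(=O)c1ccc(-c2ccco2)cc1` the atoms stay the same but are joined differently (2-carboxy-1-methylethenyl in place of 2-carboxyprop-1-en-1-yl on a saturated chain carbon, three bonds along the chain from an oxygen on an aromatic ring) on that chain. Within the data shown here, no measured step makes this exact change. The largest step, a 10-fold higher number from compound 1 to compound 2 (1.02 log units; beyond the scatter) for methyl in place of hydrogen on a saturated chain carbon bound to a carbonyl carbon, ends in a saturated chain, whereas compound 4 keeps an unsaturated chain. Compound 3 at 1300 ng.h/mL is therefore the closer guide, and compound 2 at 11400 ng.h/mL only widens the upper side of the range. No step beyond the scatter is expected in this assay in either direction. The expected step is a 1.2-fold higher number from compound 3 to compound 4 (0.06 log units; within the scatter) in size. Compound 4 is estimated at 1500 ng.h/mL with an expected range from 450 ng.h/mL to 5500 ng.h/mL in this series.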

Compound 4, area under the concentration-time curve: 4700 ng.h/mL
The estimate for compound 4 lay 3.1-fold (0.50 log units) below the measured number, and the stated range covers the measured number.
By their numbers in this assay, from the lowest: compounds 1 and 3 (each within the scatter of the next); then compound 4; then compound 2.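

Among these compounds, exchanging 2-carboxyprop-1-en-1-yl for 2-carboxy-1-methylethenyl leaves the heavy atoms and the double-bond count unchanged, yet in this assay it gives a 3.6-fold higher number from compound 3 to compound 4 (0.56 log units; beyond the scatter), so at this place on the chain the way the same atoms are joined changes the number, which the earlier compounds could not show. An unsaturated chain is therefore not confined to the low end of the series, as a 4.3-fold higher number from compound 1 to compound 4 (0.63 log units; beyond the scatter) shows, although the saturated 2-carboxypropyl chain still leads, with a 2.4-fold lower number from compound 2 to compound 4 (0.38 log units; beyond the scatter). Nothing measured here bears on the reason for either difference.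

The compounds shown leave open whether 2-carboxy-1-methylethenyl keeps this number on a longer chain, and whether an ethyl group in place of its methyl moves the number further. On these data alone, it also remains open whether the double bond itself contributes, which a saturated chain carrying the methyl on the same carbon as in compound 4 would test.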